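Swapping an Anilide for an Isopentylamide: an Expected Tolerability

The compounds below may be only part of what the source reports. "The series", "measured", "known", "first", "only" and "open" are said of these compounds alone.

Four compounds share one core. Compound 1 `COC(=O)c1c([N+](=O)[O-])noc1-c1cccc([N+](=O)[O-])c1` and compound 3 `O=C(Nc1ccccc1)c1c([N+](=O)[O-])noc1-c1ccc([N+](=O)[O-])cc1` were each tested in an ADME assay on J774.A1 cells (Mus musculus) for cytotoxicity, read by MTT assay, with a stated time of 48 h (a higher number here means that more compound is tolerated, a lower number that less compound is tolerated), without a reported number: compound 1 gives "not determined" (no result reported) and compound 3 gives "not determined" (no result reported). Compound 2 `COC(=O)c1c([N+](=O)[O-])noc1-c1ccc(Cl)cc1Cl` is the only one with a figure; in this assay compound 2 gives 19700 nM. Compound 3 thus stands without a number, beside one further entry in the same position. Compound 4 `CC(C)CCNC(=O)c1c([N+](=O)[O-])noc1-c1ccc([N+](=O)[O-])cc1` is not yet measured and differs from compound 3 by isopentyl in place of phenyl on an amide-type nitrogen. Among the compounds with values here, no measured pair shows this change, so in this assay a shift no larger than the usual scatter is expected, in either direction. Compound 4 is therefore estimated at about 20000 nM, within a range from 5000 nM to 80000 nM.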

Compound 4, half-maximal cytotoxic concentration: 67000 nM
Beside the measured number, compound 4's estimate is 3.4-fold (0.53 log units) below it, within the range that was stated.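

Within the data shown here, compound 3 has no number in this assay, so no step from it to compound 4 can be read. The compounds shown leave open what isopentyl in place of phenyl on an amide-type nitrogen does to tolerance. No supporting data bear on this result.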